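Aryl swap on the triazole nitrogen: compound 2 to compound 3

This account rests on a few compounds, and the source may have more. Where it says the series, first, only, none or still open, it means among the compounds named here.

Values in a functional assay on SK-OV-3 cells (Homo sapiens) for antiproliferative activity, read by MTT assay, with a stated time of 72 h; a higher number here means a weaker inhibitor of growth, a lower number a stronger inhibitor of growth:
compound 1 `Cc1c(C(=O)Nc2ccc(SC#N)cc2)nnn1-c1ccc(C(C)C)cc1`: 10000 nM
compound 2 `Cc1ccc(-n2nnc(C(=O)Nc3ccc(SC#N)cc3)c2C)cc1C`: > 100000 nM

Compound 2 gives only a limit of the assay, > 100000 nM, and no number.

Compound 3 `Cc1ccc(Cl)cc1-n1nnc(C(=O)Nc2ccc(SC#N)cc2)c1C` carries 5-chloro-2-methylphenyl in place of 3,4-dimethylphenyl on an aromatic nitrogen. Among the measured compounds shown here, the one measured step at this place is an at least 10-fold higher number from compound 1 to compound 2 (1.00 log units; beyond the scatter), so a swap there can move the number beyond the scatter. In this assay a modest move to a lower number is expected, though another limit remains quite possible. The expected step is an at least 1.6-fold lower number from compound 2 to compound 3 (0.22 log units; that floor lies within the scatter). The estimate for compound 3 is 60000 nM, with an expected range of 15000 nM to 150000 nM.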

Compound 3, concentration for 50% growth inhibition: 81500 nM
Compound 3: middle estimate off by 1.4-fold (0.13 log units), on the low side; measured number inside the range.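

In this assay, 5-chloro-2-methylphenyl on the aromatic nitrogen gives a measured number, but 4-isopropylphenyl remains the better group here: an 8.2-fold higher number from compound 1 to compound 3 (0.91 log units; beyond the scatter). Against 3,4-dimethylphenyl, the change reads only as an at least 1.2-fold lower number from compound 2 to compound 3 (0.08 log units; that floor lies within the scatter), so no gain can be claimed. Compound 2 stands at a limit of the assay, not a number: the limit of > 100000 nM in this assay, at which 1 of the 3 values shown sits.

Still open, from the compounds shown here alone, is whether the chlorine or the placing of the methyl group sets the value of compound 3. It is also unknown whether a methoxy group or an amine on this aryl ring would bring the number nearer that of compound 1.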